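Replacing the triazolylmethyl group: outlook for compound 3

The source may hold more compounds than are shown below. What is called first, only, known or untested is meant among the compounds shown, and "the series" means these compounds.

Going by the values given here, compound 2 `Cc1c(Cc2ccccc2Cn2ccnn2)c2c(n1CC(=O)O)CCNC2=O` is the weaker of the two measured members. In a functional assay on CHO.K1 cells for antagonist activity at prostaglandin D2 receptor 2 (Homo sapiens), read by GTPgammaS binding, with a stated time of 1 h (a higher number here means a weaker inhibitor, a lower number a stronger inhibitor), compound 2 gives 800 nM, whereas compound 1 `Cc1c(Cc2ccccc2S(=O)(=O)c2ccccc2F)c2c(n1CC(=O)O)CCNC2=O` gives 3.6 nM. Among the compounds with values here, the only measured step, a 220-fold higher number from compound 1 to compound 2 (2.35 log units; beyond the scatter), shows that the group on this aromatic carbon moves the number a long way. Compound 3 `Cc1c(Cc2ccccc2-c2cccc3ccccc23)c2c(n1CC(=O)O)CCNC2=O` differs from compound 2 by naphthalen-1-yl in place of (1H-1,2,3-triazol-1-yl)methyl on an aromatic carbon. Within the data shown here, no measured step tests a naphthalen-1-yl group directly, but the step from compound 1 to compound 2 shows that an aromatic substituent at this carbon, as in compound 1 with 3.6 nM, gives a far lower number than the triazolylmethyl group does. Compound 3 again carries a two-ring aromatic group there, so a lower number is expected, with a 20-fold lower number from compound 2 to compound 3 (1.30 log units; beyond the scatter) as the estimated step. The size is uncertain, since compound 3 lacks the sulfonyl link of compound 1. Compound 3 is therefore estimated at 40 nM, with a range of 6 nM to 300 nM.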

Compound 3, half-maximal inhibitory concentration: 480 nM
Compound 3: the middle estimate sits 12-fold (1.08 log units) below what was measured; measured number above the stated range.
By their numbers in this assay, from the lowest: compound 1; then compounds 3 and 2 (each within the scatter of the next).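

In this assay, naphthalen-1-yl in place of (1H-1,2,3-triazol-1-yl)methyl gives a 1.7-fold lower number from compound 2 to compound 3 (0.22 log units; within the scatter), so this read-out does not separate these two groups on this aromatic carbon, even though one brings two six-membered aromatic rings of carbon only and the other a five-membered aromatic ring with hetero atoms. The large gap remains with the (2-fluorophenyl)sulfonyl group, as a 130-fold higher number from compound 1 to compound 3 (2.12 log units; beyond the scatter) shows, so among these compounds an aromatic group at this carbon does not in itself match compound 1. No available evidence bears on the reason for this gap. Still open, as far as these compounds go, is whether the sulfonyl link, the 2-fluorophenyl ring or both account for the number of compound 1. A methylsulfonyl group, a phenylsulfonyl group without fluorine or a benzoyl group at this carbon would help to separate these parts.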